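Swapping a Furan for Naphthalene on a Shared Core

The source may report more compounds than this note shows. Statements on the series, on what has been measured and on what is new or still open speak of the compounds shown alone.

Compound 1 `CC(C)c1nn(-c2ccc(C(N)=O)c(N[C@H]3CC[C@H](O)CC3)c2)c2nccc(-n3cnc(-c4cncnc4)c3)c12` gives 387 nM in a functional assay on SK-BR-3 cells (Homo sapiens) for inhibition, read by CellTiter-Glo, with a stated time of 72 h; a higher number here means a weaker inhibitor, a lower number a stronger inhibitor. Compound 2 `CC(C)c1nn(-c2ccc(C(N)=O)c(N[C@H]3CC[C@H](O)CC3)c2)c2nccc(-c3ccoc3)c12` gives only a limit in this assay, namely > 10000 nM. That value is the limit of > 10000 nM in this assay, at which 1 of the 2 values shown sits. Within the data shown here, the one measured change, an at least 25-fold higher number from compound 1 to compound 2 (1.41 log units; beyond the scatter), shows how much this position of the core matters. Compound 3 `CC(C)c1nn(-c2ccc(C(N)=O)c(N[C@H]3CC[C@H](O)CC3)c2)c2nccc(-c3ccc4ccccc4c3)c12` differs from compound 2 by naphthalen-2-yl in place of furan-3-yl on an aromatic carbon. Among the measured compounds shown here, no measured step covers a ring of carbon only, and the single step known is large and loses potency, so compound 3 is expected to remain weak. For compound 3 the estimate is 12000 nM, within 2500 nM to 50000 nM. The step that the limit leaves unreadable from compound 2 to compound 3 is expected to stay within the scatter.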

Compound 3, half-maximal inhibitory concentration: > 10000 nM
Compound 3 gave a limit, no number; the forecaster's own chance of this, stated with the estimate: 65%; the middle value lies beyond the limit too.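

In this assay, naphthalen-2-yl on this aromatic carbon gives an at least 25-fold higher number from compound 1 to compound 3 (1.41 log units; beyond the scatter), so rings of carbon only in place of furan-3-yl do not bring back a measurable value. The step from compound 2 to compound 3 cannot be read, because both values are limits and not numbers: the limit of > 10000 nM in this assay, at which 2 of the 3 values shown sit.

Still open, on these data alone, is which part of 4-(pyrimidin-5-yl)-1H-imidazol-1-yl carries the activity of compound 1. Also open, as far as these compounds go, is whether an amine or a carboxylic acid on this carbon would give a number rather than a limit.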